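The source may report more compounds than this note shows. Statements on the series, on what has been measured and on what is new or still open speak of the compounds shown alone.

Compound 1 `O=C(CCc1cccc2c1B(O)OC2)Nc1ccccc1` gives 200 nM in a functional assay on SK-OV-3 cells (Homo sapiens) for antiproliferative activity, read by MTT assay, with a stated time of 72 h; a lower number here means a stronger inhibitor, a higher number a weaker inhibitor.
Compound 2 `O=C(CCc1cccc2c1B(O)OC2)Nc1nccs1` gives > 100000 nM in this assay, which is a limit, not a number.

Going by these compounds, compound 2 thus stands at the limit of this assay (the limit of > 100000 nM in this assay, at which 1 of the 2 values shown sits), so its true number is unknown. Among the compounds with values here, only one measured step bears on the change at hand: an at least 500-fold higher number from compound 1 to compound 2 (2.69 log units; beyond the scatter). Compound 3 `O=C(CCc1cccc2c1B(O)OC2)Nc1cccc(Br)c1` carries the reverse kind of change at the same place: 3-bromophenyl in place of 1,3-thiazol-2-yl on an amide-type nitrogen. With 3-bromophenyl on the amide-type nitrogen, compound 3 resembles compound 1 more than compound 2, so the expected step is a large fall in the number, roughly undoing the rise seen from compound 1 to compound 2; the step expected is an at least 400-fold lower number from compound 2 to compound 3 (2.60 log units; beyond the scatter). Compound 3 is therefore estimated at 250 nM, with a range of 50 nM to 2000 nM. The estimate is wide, resting on a single measured step and on a starting value that is itself only a limit.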

Compound 3, half-maximal inhibitory concentration: 540 nM
Compound 3: the middle estimate sits 2.2-fold (0.33 log units) below what was measured; measured number inside the range.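

In this assay, the phenyl amide tolerates a bromo group with only a modest loss: a 2.7-fold higher number from compound 1 to compound 3 (0.43 log units; beyond the scatter). Exchanging 1,3-thiazol-2-yl for 3-bromophenyl on the amide-type nitrogen brings back activity in the same range as compound 1, with an at least 180-fold lower number from compound 2 to compound 3 (2.26 log units; beyond the scatter), so among these three compounds the two carrying a six-membered aromatic ring of carbon only are active, and compound 2 is the one that falls away. The value of compound 2 is a limit and not a number, so that step gives only a minimum size: the limit of > 100000 nM in this assay, at which 1 of the 3 values shown sits.

Going by these compounds, it remains open whether the loss extends to other aromatic rings with hetero atoms, such as a pyridine ring. A chloro group or an amine on the phenyl ring would show whether the modest step belongs to bromo in particular.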